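The compounds below may be only part of what the source reports. "The series", "measured", "known", "first", "only" and "open" are said of these compounds alone.

Compound 1 `C=C(C)c1ccccc1OC(C)C1=NCCN1` gives 0.4 in an assay on CHO cells with Alpha-2B adrenergic receptor (Homo sapiens) as the target; a lower number here means a smaller maximal response, a higher number a larger maximal response.
Compound 2 `CC(Oc1ccccc1S(C)(=O)=O)C1=NCCN1` gives 0.45 in this assay.

Compound 2 holds the higher of the two numbers, but the step a number 0.050 higher from compound 1 to compound 2 (within the scatter) lies within the scatter, so the two compounds cannot be told apart. Compound 3 `C=COc1ccccc1OC(C)C1=NCCN1` differs from compound 2 by vinyloxy in place of methylsulfonyl on an aromatic carbon. Within the data shown here, only one measured step, a number 0.050 higher from compound 1 to compound 2 (within the scatter), exchanged a group at that same place, and it stayed within the scatter. No measurement shows how vinyloxy behaves, so no step beyond the scatter is expected in this assay; the change for compound 3 is estimated at a number 0.050 lower from compound 2 to compound 3 (within the scatter). Compound 3 is therefore expected to give 0.4, within a range from 0.25 to 0.6.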

Compound 3, intrinsic activity: the largest response reached, as a fraction of the reference agonist's: 0.45
For compound 3 the middle estimate is 0.050 below the measured one; the measured number falls inside the stated range.
By their numbers in this assay, from the lowest: compounds 1, 2 and 3 (each within the scatter of the next).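

At this aromatic carbon, vinyloxy in place of methylsulfonyl gives no change at the digits printed from compound 2 to compound 3 (within the scatter) in this assay, and vinyloxy in place of 1-methylethenyl gives a number 0.050 higher from compound 1 to compound 3 (within the scatter). Three different groups have now been placed here, and the maximal responses of the three compounds cannot be told apart. No measured evidence is available to explain this result. On these data alone, it remains open whether an amine, a carboxylic acid or a longer chain at this same place would shift the maximal response beyond the scatter.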